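Cyclic urea alkyne series: agonist dose in the mouse

The source may report more compounds than this note shows. Statements on the series, on what has been measured and on what is new or still open speak of the compounds shown alone.

Measured compounds:
compound 1 `O=C1NCCN1CC#CCn1ccnc1` — 30 mg/kg
compound 2 `CN(C)CC#CCN1CCNC1=O` — 9.7 mg/kg
compound 3 `Cn1ccn(CC#CCn2ccnc2)c1=O` — 4.4 mg/kg

In a functional assay on the whole organism for agonist activity, with Mus musculus as the target (a lower number here means that less compound is needed, a higher number that more compound is needed for the effect), compound 1 gives 30 mg/kg and compound 2 gives 9.7 mg/kg. Within the data shown here, the single change between them is dimethylamino in place of 1H-imidazol-1-yl on a saturated chain carbon bound to a triple-bonded carbon and it gave a 3.1-fold lower number from compound 1 to compound 2 (0.49 log units; beyond the scatter). Compound 3, with a different core, gives 4.4 mg/kg in this assay, the lowest of the three numbers. How the core of compound 3 differs from that of compound 1 is not broken down here.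

Compound 4 `CN(C)CC#CCn1ccn(C)c1=O` is not yet measured. It differs from compound 3 by dimethylamino in place of 1H-imidazol-1-yl on a saturated chain carbon bound to a triple-bonded carbon, the same change seen from compound 1 to compound 2. Compound 4 is expected to give 1.6 mg/kg in this assay, a range of 0.7 mg/kg to 4 mg/kg. Compound 4 is estimated to show a 2.8-fold lower number from compound 3 to compound 4 (0.44 log units; beyond the scatter), set slightly smaller than the earlier step because a 3.1-fold lower number from compound 1 to compound 2 (0.49 log units; beyond the scatter) rests on a single pair.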

Compound 4, dose for half-maximal effect: 8 mg/kg
The estimate for compound 4 lay 5.0-fold (0.70 log units) below the measured number; measured number outside the range, above it.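

In this assay, dimethylamino in place of 1H-imidazol-1-yl gives a 1.8-fold higher number from compound 3 to compound 4 (0.26 log units; within the scatter), so the change does not carry over from one core to the other with its earlier effect: the same change on two cores in this assay, a 3.1-fold lower number (0.49 log units; beyond the scatter) from compound 1 to compound 2 and a 1.8-fold higher number (0.26 log units; within the scatter) from compound 3 to compound 4, 5.6-fold (0.75 log units) apart, beyond the scatter of two such steps. The outcome of this change therefore depends on the core in these two pairs, and the lower number seen on the core of compound 1 cannot be assumed on another core. The two pairs do not show which feature of the cores is responsible, nor what the change would do on a third core.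

Going by these compounds, it remains open whether a cyclic amine such as pyrrolidine or morpholine at this place would also differ between the two cores. On these data alone, the effect of a longer chain on either core also remains open.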